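Amide-side amine swap in the fluorinated sulfoxide series

A few compounds are considered here, and "the series" means these few. Any claim that something is new, unique, unknown or untested is made for them only; others in the source may bear on it.

Working notes on three measured amides and one open analogue. In a functional assay on HT-29 cells (Homo sapiens) for inhibition, read by CellTiter-Glo, with a stated time of 72 h (a lower number here means that less compound is tolerated, a higher number that more compound is tolerated), compound 1 `CC1=C(C(C)C(=O)NCCN(C)C)c2cc(F)ccc2/C1=C\c1ccc([S+](C)[O-])cc1` gives 12700 nM and compound 2 `CC1=C(C(C)C(=O)NCCN2CCCC2)c2cc(F)ccc2/C1=C\c1ccc([S+](C)[O-])cc1` gives 13700 nM, a pair separated only by a 1.1-fold higher number from compound 1 to compound 2 (0.03 log units; within the scatter). Compound 3 `CC1=C(C(C)C(=O)NCCN2CCNCC2)c2cc(F)ccc2/C1=C\c1ccc([S+](C)[O-])cc1` reaches only the limit > 50000 nM in this assay, so it stands as a bound, not a number. The two steps leading there, an at least 3.9-fold higher number from compound 1 to compound 3 (0.59 log units; beyond the scatter) and an at least 3.6-fold higher number from compound 2 to compound 3 (0.56 log units; beyond the scatter), both run upward and beyond the scatter; the evidence for them rests on (the limit of > 50000 nM in this assay, at which 1 of the 3 values shown sits).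

The open analogue is compound 4 `CC1=C(C(C)C(=O)N2CCN(CCCN(C)C)CC2)c2cc(F)ccc2/C1=C\c1ccc([S+](C)[O-])cc1`, which differs from compound 3 by 4-(3-(dimethylamino)propyl)piperazin-1-yl in place of (2-(piperazin-1-yl)ethyl)amino on a carbonyl carbon. For the measured compounds named here, no measured step changes the amide nitrogen itself, so the three steps bear on it only indirectly: the entering group restores a dimethylamino terminus of the kind present in compound 1, whose value in this assay is 12700 nM. The step from compound 3 to compound 4 is therefore expected to run downward, roughly as an at least 2.5-fold lower number from compound 3 to compound 4 (0.39 log units; beyond the scatter). Compound 4 is accordingly estimated at 20000 nM, with an expected range from 6000 nM to 60000 nM.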

Compound 4, half-maximal cytotoxic concentration: 32000 nM
Beside the measured number, compound 4's estimate is 1.6-fold (0.20 log units) below it; measured number inside the range.
By their numbers in this assay, from the lowest: compounds 1 and 2 (each within the scatter of the next); then compound 4. At a limit, above all of these: compound 3.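

In this assay, the carbonyl carbon carrying 4-(3-(dimethylamino)propyl)piperazin-1-yl gives a measured number that stands apart from both earlier measured amides: a 2.5-fold higher number from compound 1 to compound 4 (0.40 log units; beyond the scatter) and a 2.3-fold higher number from compound 2 to compound 4 (0.37 log units; beyond the scatter). A dimethylamino terminus alone therefore does not return the series to the number of compound 1, so the terminus shared by these two compounds does not settle the value at this position. Against the limit compound the step is an at least 1.5-fold lower number from compound 3 to compound 4 (0.19 log units; that floor lies within the scatter), so the order of those two stays unsettled, and this reading rests on a limit: the limit of > 50000 nM in this assay, at which 1 of the 4 values shown sits.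

Compound 4 changes the amide nitrogen, the chain and the ring together, so the compounds shown do not separate these changes. A (3-(dimethylamino)propyl)amino group or a 4-methylpiperazin-1-yl group on the same carbonyl carbon would begin to divide them.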